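The source may report more compounds than this note shows. Statements on the series, on what has been measured and on what is new or still open speak of the compounds shown alone.

Measured compounds:
compound 1 `C=CCNc1nc(NCc2ccc(C(=O)Nc3ccc(F)cc3)cc2)c2ccccc2n1` — 14000 nM
compound 2 `CCCNc1nc(NCc2ccc(C(=O)Nc3ccc(F)cc3)cc2)c2ccccc2n1` — 1500 nM
compound 3 `CNc1nc(NCc2ccc(C(=O)Nc3ccc(F)cc3)cc2)c2ccccc2n1` — 2900 nM

In a functional assay on HCT-116 cells (Homo sapiens) for inhibition, read by luminescence and resazurin assay, with a stated time of 3 days (on this read-out higher numbers stand for weaker inhibition and lower numbers for stronger inhibition), compound 3 stands second highest of the three numbers. Its nearest neighbour is compound 2: a 1.9-fold higher number from compound 2 to compound 3 (0.29 log units; within the scatter). The furthest is compound 1: a 4.8-fold lower number from compound 1 to compound 3 (0.68 log units; beyond the scatter).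

Compound 4 `CC1CN(c2nc(NCc3ccc(C(=O)Nc4ccc(F)cc4)cc3)c3ccccc3n2)CCN1` differs from compound 3 by 3-methylpiperazin-1-yl in place of methylamino on an aromatic carbon. Every measured step concerns the same aromatic carbon and swaps one small chain for another, the largest being a 9.3-fold lower number from compound 1 to compound 2 (0.97 log units; beyond the scatter), the other 4.8-fold lower number from compound 1 to compound 3 (0.68 log units; beyond the scatter); none introduces a ring, so they bear only loosely on this change. Since these swaps moved the numbers by modest amounts at most, compound 4 is expected to land near compound 3, with a step of a 1.2-fold lower number from compound 3 to compound 4 (0.06 log units; within the scatter) that may well fall within the scatter. Compound 4 is therefore estimated at 2500 nM, between 700 nM and 9000 nM.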

Compound 4, half-maximal inhibitory concentration: 2800 nM
Compound 4: the middle estimate sits 1.1-fold (0.05 log units) below what was measured; the range from low to high includes it.
By their numbers in this assay, from the lowest: compounds 2, 4 and 3 (each within the scatter of the next); then compound 1.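

In this assay, this carbon between two ring nitrogen atoms takes a six-membered non-aromatic ring without leaving the range of the small chains: 3-methylpiperazin-1-yl reads level with methylamino (a 1.0-fold lower number from compound 3 to compound 4 (0.02 log units; within the scatter)) and with propylamino (a 1.9-fold higher number from compound 2 to compound 4 (0.27 log units; within the scatter)). Allylamino stays apart from it (a 5.0-fold lower number from compound 1 to compound 4 (0.70 log units; beyond the scatter)), so among these four compounds only compound 1 stands away from the others. Nothing available explains these results.

Going by these compounds, it remains open whether an unsubstituted piperazine, a morpholine or a longer chain would read alike at this carbon. On these data alone, the contribution of the methyl on the ring also remains open.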